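This account rests on a few compounds, and the source may have more. Where it says the series, first, only, none or still open, it means among the compounds named here.

In an ADME assay on NCM460 cells (Homo sapiens) for cytotoxicity, read by CCK-8 assay, with a stated time of 48 h (on this read-out higher numbers stand for weaker inhibition and lower numbers for stronger inhibition), compound 1 `COc1ccc(/C=C\c2cc(OC)c(OC)c(OC)c2)cc1OCc1ccc(CNC(C)(C)C(=O)O)cc1` gives > 50000 nM, which is a limit and not a number. Compound 2 `COc1ccc(/C=C\c2cc(OC)c(OC)c(OC)c2)cc1OCc1ccc(CN2CCCC[C@@H]2C(=O)O)cc1` gives > 50000 nM, also a limit. Compound 3 `COc1ccc(/C=C\c2cc(OC)c(OC)c(OC)c2)cc1OCc1ccc(CN[C@H](C(=O)O)[C@H](C)O)cc1` gives > 50000 nM, again a limit. Together they form (the limit of > 50000 nM in this assay, at which 3 of the 3 values shown sit). The measured changes are a step that the two limits leave unreadable from compound 1 to compound 2, a step that the two limits leave unreadable from compound 1 to compound 3 and a step that the two limits leave unreadable from compound 2 to compound 3, so none offers a size to carry over. Compound 4 `COc1ccc(/C=C\c2cc(OC)c(OC)c(OC)c2)cc1OCc1ccc(CNCCO)cc1` has 2-hydroxyethyl in place of 1-carboxy-1-methylethyl on an amine nitrogen. Unlike compounds 1, 2 and 3, it has no carboxy group in this piece, and this change is untested. The expected result is an at least 1.4-fold lower number from compound 1 to compound 4 (0.15 log units; that floor lies within the scatter), a modest estimated move towards stronger inhibition, though another limit remains quite possible. For compound 4 the estimate is 35000 nM, with an expected range of 8000 nM to 80000 nM.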

Compound 4, half-maximal inhibitory concentration: 39000 nM
Compound 4: the middle estimate sits 1.1-fold (0.05 log units) below what was measured; the range from low to high includes it.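

Compound 4, with 2-hydroxyethyl on the amine nitrogen and no carboxy group in this piece, is the only one of the four to give a number rather than a limit in this assay. The other three compounds stay at a limit: the limit of > 50000 nM in this assay, at which 3 of the 4 values shown sit. The steps are an at least 1.2-fold lower number from compound 1 to compound 4 (0.10 log units; that floor lies within the scatter), an at least 1.2-fold lower number from compound 3 to compound 4 (0.10 log units; that floor lies within the scatter) and an at least 1.2-fold lower number from compound 2 to compound 4 (0.10 log units; that floor lies within the scatter), so none of them establishes a real change.

This single swap both removes the carboxy group and changes the chain, leaving the two effects unseparated. Going by these compounds, how a longer chain such as 3-hydroxypropyl, or a plain ethyl group, would read remains open.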